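The compounds below may be only part of what the source reports. "The series", "measured", "known", "first", "only" and "open" are said of these compounds alone.

Measured compounds in this series:

Compound 1 `Cc1ccc(-n2cc(C(=O)Nc3cc(F)cc(F)c3)c(=O)c3ccc(N(C)C)nc32)cc1OCCCCCCC[N+]12CCN(CC1)CC2` — in an assay on LX2 cells for inhibition of COL1A1 promoter (Homo sapiens), read by a luciferase reporter, with a stated time of 24 h, tested at 50 uM (on this read-out lower numbers stand for a weaker effect and higher numbers for a stronger effect at the one concentration tested), compound 1 gives 9.71%.
Compound 2 `CN(C)c1ccc2c(=O)c(C(=O)Nc3cc(F)cc(F)c3)cn(-c3ccc(Cl)c(OCCCCCCC[N+]45CCN(CC4)CC5)c3)c2n1` — in this assay compound 2 gives 18.7%.
Compound 3 `CC[N+]1(CCCCCCCOc2ccc(-n3cc(C(=O)Nc4cc(F)cc(F)c4)c(=O)c4ccc(N(C)C)nc43)cc2C)CCCCC1` — in this assay compound 3 gives 53.4%.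

Compound 1 and compound 2 differ in one place, (chloro in place of methyl on an aromatic carbon), and this gave a number 9 percentage points higher from compound 1 to compound 2 (within the scatter). The difference between the core of compound 1 and the core of compound 3 is not broken down here; compound 3 gives the highest of the three numbers, beyond the scatter from both others.

Compound 4 `CC[N+]1(CCCCCCCOc2ccc(-n3cc(C(=O)Nc4cc(F)cc(F)c4)c(=O)c4ccc(N(C)C)nc43)cc2Cl)CCCCC1` is not yet measured. It relates to compound 3 by chloro in place of methyl on an aromatic carbon. This is the same kind of change as that from compound 1 to compound 2, but the surroundings differ: in compound 2 the place is para to a large group, in compound 4 it is meta to a large group. Since the earlier step was within the scatter, the step for compound 4 is expected to be small, about a number 4.6 percentage points higher from compound 3 to compound 4 (within the scatter), resting on compound 3 at 53.4%. Compound 4 is therefore estimated at 58%, with a range from 40% to 75%.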

Compound 4, a percentage reported as inhibition, at one concentration (the size of the read-out at that concentration, not a potency): 50.4%
Beside the measured number, compound 4's estimate is 7.6 percentage points above it; measured number inside the range.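

In this assay, chloro in place of methyl on an aromatic carbon gives a number 3 percentage points lower from compound 3 to compound 4 (within the scatter), and this step can be set against the earlier one: the same change on two cores in this assay, a number 9 percentage points higher (within the scatter) from compound 1 to compound 2 and a number 3 percentage points lower (within the scatter) from compound 3 to compound 4, 12 percentage points apart, within the scatter of two such steps. On these two cores, then, the change leaves the read-out within the scatter, and the two steps do not differ from each other. This does not show that the change would stay as small on any other core, and two pairs read at one concentration give neither a potency nor a cause for either step.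

Open, going by these compounds, is whether bromo, methoxy or trifluoromethyl at the same place would read like methyl and chloro. Also open, on these data alone, is whether a shorter chain would alter the size of this step.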